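A few compounds are considered here, and "the series" means these few. Any claim that something is new, unique, unknown or untested is made for them only; others in the source may bear on it.

Compound 1 `CC1CCCCC1NC(=O)[C@H]1OC(n2cnc3c(N)ncnc32)[C@H](O)[C@@H]1O` gives 69.5 nM in an assay on cell membranes for binding affinity to 2-oxoglutarate receptor 1 (Rattus norvegicus), read by radioligand binding; on this read-out higher numbers stand for weaker inhibition and lower numbers for stronger inhibition. Compound 2 `Nc1ncnc2c1ncn2C1O[C@H](C(=O)NC2CC3CCC2C3)[C@@H](O)[C@H]1O` gives 640 nM in this assay.

Among the compounds with values here, compound 2 thus holds the higher of the two numbers; the single measured step is a 9.2-fold higher number from compound 1 to compound 2 (0.96 log units; beyond the scatter). Compound 3 `Nc1ncnc2c1ncn2C1O[C@H](C(=O)NO)[C@@H](O)[C@H]1O` differs from compound 2 by one oxygen atom in place of a group of 7 heavy atoms (7 carbon; 2 five-membered non-aromatic rings of carbon only), on an amide-type nitrogen. Within the data shown here, only that one step bears on this change, and it shows that an exchange of the group on the amide nitrogen already shifted the number beyond the scatter in a 9.2-fold higher number from compound 1 to compound 2 (0.96 log units; beyond the scatter); a change to hydroxy is expected to shift it further upward. Compound 3 is estimated at 6000 nM (range 1000 nM to 40000 nM), an expected step of a 9.4-fold higher number from compound 2 to compound 3 (0.97 log units; beyond the scatter).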

Compound 3, inhibition constant: 41 nM
For compound 3 the middle estimate is 150-fold (2.17 log units) above the measured one; measured number below the stated range.
By their numbers in this assay, from the lowest: compounds 3 and 1 (each within the scatter of the next); then compound 2.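

In this assay, one oxygen atom on the amide-type nitrogen in place of the group of 7 heavy atoms gives a 16-fold lower number from compound 2 to compound 3 (1.19 log units; beyond the scatter), so a carbon ring group is not required at this position for a low number. Hydroxy in place of 2-methylcyclohexyl gives a 1.7-fold lower number from compound 1 to compound 3 (0.23 log units; within the scatter), so these two very different groups cannot be told apart on this read-out. No evidence is available to explain either step.

From the compounds shown here alone, it remains open whether methoxy, an amine or a small alkyl group such as methyl on this nitrogen would give a similar number, and whether a longer chain would fall with the ring groups.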